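The source may hold more compounds than are shown below. What is called first, only, known or untested is meant among the compounds shown, and "the series" means these compounds.

Series notes. an in vitro functional assay on cells (Fibroblast) for agonist activity at Alpha-1A adrenergic receptor (Homo sapiens) (a lower number here means that less compound is needed, a higher number that more compound is needed for the effect), has been run on three compounds so far. Compound 1 `c1ccc(-c2nc[nH]n2)c(NCC2=NCCN2)c1` gives 0.794 nM; compound 2 `Cn1ccc(-c2ccccc2NCC2=NCCN2)n1` gives 3.16 nM; compound 3 `CCn1ccc(-c2ccccc2NCC2=NCCN2)n1` gives 25.1 nM. On these numbers compound 2 stands second highest, with a 4.0-fold higher number from compound 1 to compound 2 (0.60 log units; beyond the scatter) and a 7.9-fold higher number from compound 2 to compound 3 (0.90 log units; beyond the scatter). Compound 4 `Cn1cccc1-c1ccccc1NCC1=NCCN1` is not yet measured; it differs from compound 2 by 1-methyl-1H-pyrrol-2-yl in place of 1-methyl-1H-pyrazol-3-yl on an aromatic carbon. The step that bears on it is a 4.0-fold higher number from compound 1 to compound 2 (0.60 log units; beyond the scatter), where 1-methyl-1H-pyrazol-3-yl replaced 1H-1,2,4-triazol-3-yl on the same aromatic carbon and the number rose; a 7.9-fold higher number from compound 2 to compound 3 (0.90 log units; beyond the scatter) concerns a different position and is less informative. The expected step is therefore a further rise beyond the scatter, a 3.2-fold higher number from compound 2 to compound 4 (0.50 log units; beyond the scatter). Compound 4 is estimated at 10 nM, within 3 nM to 40 nM.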

Compound 4, half-maximal effective concentration: 20 nM
Compound 4: the middle estimate sits 2.0-fold (0.30 log units) below what was measured; the measured number falls inside the stated range.
By their numbers in this assay, from the lowest: compound 1; then compound 2; then compounds 4 and 3 (each within the scatter of the next).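

In this assay this aromatic carbon responds even when the ring keeps its 6 heavy atoms and gains no hydrogen-bond donor: 1-methyl-1H-pyrrol-2-yl in place of 1-methyl-1H-pyrazol-3-yl gives a 6.3-fold higher number from compound 2 to compound 4 (0.80 log units; beyond the scatter) at this position. Against 1H-1,2,4-triazol-3-yl the same group gives a 25-fold higher number from compound 1 to compound 4 (1.40 log units; beyond the scatter) and so extends the rise across these three rings. No available data account for this rise.

Going by these compounds, whether it follows the lost ring nitrogen or the changed point of attachment remains open; 1-methyl-1H-pyrazol-5-yl would separate the two. A plain phenyl on this carbon is also an open case.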